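Trading Ethyl for Trifluoromethyl on the Compound 2 Chain

The compounds below may be only part of what the source reports. "The series", "measured", "known", "first", "only" and "open" are said of these compounds alone.

In an ADME assay on a cell-free system (plasma, Homo sapiens) for protein binding (a higher number here means a larger unbound share of the compound, a lower number a smaller unbound share), compound 1 (`CCCOc1nc(OCC(C)(C)O)c(-c2ccc(S(C)(=O)=O)cc2)cc1CO`) gives 0.016. Compound 2 (`CCCCOc1nc(OCC(C)(C)O)c(-c2ccc(S(C)(=O)=O)cc2)cc1CO`) gives 0.009, which lies within the scatter of compound 1, so the two cannot be told apart on these numbers.

The next structure, compound 3 (`CC(C)(O)COc1nc(OCCC(F)(F)F)c(CO)cc1-c1ccc(S(C)(=O)=O)cc1`), has not yet been measured. It differs from compound 2 in a single place: trifluoromethyl in place of ethyl on a saturated chain carbon, two bonds along the chain from an oxygen on an aromatic ring. Seen one bond further out, butoxy becomes 3,3,3-trifluoropropoxy.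

Among the measured compounds shown here, only one measured step touches this chain: a 1.8-fold lower number from compound 1 to compound 2 (0.25 log units; within the scatter). That step is a methyl in place of hydrogen, so it shows a small shift for a chain change but contains no fluorine. For the measured compounds named here, nothing measured so far shows what trifluoromethyl does, which leaves the forecast loose. No step beyond the scatter is expected in this assay, and the estimated change is a 1.3-fold higher number from compound 2 to compound 3 (0.12 log units; within the scatter). For compound 3 the expected value is 0.012, with an estimated range from 0.006 to 0.024.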

Compound 3, unbound fraction: 0.01
For compound 3 the middle estimate is 1.2-fold (0.08 log units) above the measured one; low and high end bracket the measured number.
By their numbers in this assay, from the lowest: compounds 2, 3 and 1 (each within the scatter of the next).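

Among the compounds shown here, this is the first fluorine on this chain, and in this assay putting trifluoromethyl in place of ethyl gives a 1.1-fold higher number from compound 2 to compound 3 (0.05 log units; within the scatter), so these two compounds cannot be told apart. Trifluoromethyl in place of methyl gives a 1.6-fold lower number from compound 1 to compound 3 (0.20 log units; within the scatter), so the propoxy, butoxy and 3,3,3-trifluoropropoxy chains all read alike on these numbers, and this place on the chain takes three fluorine atoms with no step that stands clear of the scatter. No measurement shown here offers an explanation for how closely these numbers sit together.

From the compounds shown here alone, all three chains hold only carbon, hydrogen and, in one case, fluorine beyond the oxygen, so it stays open whether an amine or a carboxylic acid in the same place would give a step beyond the scatter. Going by these compounds, it is also open whether a cyclopropyl group would read the same here, or whether a trifluoromethyl group at the end of a longer chain would still match its unfluorinated partner.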